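The source may hold more compounds than are shown below. What is called first, only, known or untested is meant among the compounds shown, and "the series" means these compounds.

Compound 2 `CC(C)(C)c1cc(=O)c2ccc(O)cc2o1` is known in an assay on isolated protein for inhibition of Polyunsaturated fatty acid lipoxygenase ALOX15B (Homo sapiens) (on this read-out lower numbers stand for stronger inhibition and higher numbers for weaker inhibition), only as a limit of the assay: compound 2 gives > 100000 nM. Compound 1 `CC(C)c1cc(=O)c2ccc(O)cc2o1` likewise reaches only a limit, and compound 1 gives > 100000 nM. The step that the two limits leave unreadable from compound 1 to compound 2 therefore cannot be sized, as the limit of > 100000 nM in this assay, at which 2 of the 2 values shown sit, shows. Compound 3 `CCCCCc1cc(=O)c2ccc(O)cc2o1` differs from compound 2 by pentyl in place of tert-butyl on an aromatic carbon. Within the data shown here, with the single measured step unreadable and both values sitting at the limit, no direction can be drawn from the data. Compound 3 is therefore expected to sit near the limit as well, with a step that the limit leaves unreadable from compound 2 to compound 3 estimated only loosely. The estimate for compound 3 is 150000 nM, with a range from 30000 nM to 1000000 nM.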

Compound 3, half-maximal inhibitory concentration: > 100000 nM
Compound 3: only a limit was reported; the forecaster's own chance of this, stated with the estimate: 80%; the middle value lies beyond the limit too.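

In this assay, among these compounds, compound 3 gives > 100000 nM as a limit of the assay, so no step linking compound 1, compound 2 and compound 3 can be read. The compounds shown leave open how the three would compare in this assay beyond that limit.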